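A carbamate in place of an ether on a shared core

The compounds below may be only part of what the source reports. "The series", "measured", "known", "first", "only" and "open" are said of these compounds alone.

Compound 1 `COc1ccc(NC(=O)Oc2cc(=O)n(CCCO)c3c2CC(CC=C(C)C)C(C)(C)C3)cc1`: 0%
Compound 2 `CCOc1cc(=O)n(CCCO)c2c1CC(C/C=C(\C)CCC=C(C)C)C(C)(C)C2`: 0.8%
Compound 3 `COc1ccc(OCCCOc2cc(=O)n(CCCO)c3c2CC(C/C=C(\C)CCC=C(C)C)C(C)(C)C3)cc1`: 0%

All three compounds were tested in a functional assay on PANC-1 cells (Homo sapiens) for inhibition, read by MTT assay, with a stated time of 24 h, tested at 10 uM; a lower number here means less inhibition, a higher number more inhibition at the concentration tested (going by the name of the read-out). Compound 3 stands level with compound 1 at the digits reported, and the two together are the lowest of the three numbers; compound 2 sits within the scatter of both, so no order among them can be read.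

Compound 4 `COc1ccc(NC(=O)Oc2cc(=O)n(CCCO)c3c2CC(C/C=C(\C)CCC=C(C)C)C(C)(C)C3)cc1` is the next compound to be measured. It differs from compound 3 in one place: (4-methoxyphenyl)carbamoyl in place of 3-(4-methoxyphenoxy)propyl on an oxygen on an aromatic ring.

Going by the values given here, the only measured step that touches this series is a number 0.8 percentage points lower from compound 2 to compound 3 (within the scatter), which changed nothing beyond the scatter. Among the compounds with values here, compound 1 already carries the group that enters here and gives 0%, so every number so far sits near zero. On this basis the expected step of a number 1 percentage points higher from compound 3 to compound 4 (within the scatter) is none beyond the scatter.

Compound 4 is therefore estimated at 1%, within a range from 0% to 8%.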

Compound 4, a percentage reported as inhibition, at one concentration (the size of the read-out at that concentration, not a potency): 0%
Beside the measured number, compound 4's estimate is 1 percentage points above it; the measured number falls inside the stated range.
By their numbers in this assay, from the lowest: compounds 1, 3, 4 and 2 (each within the scatter of the next).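

At the oxygen on the aromatic ring, the 3-(4-methoxyphenoxy)propyl group gives way to (4-methoxyphenyl)carbamoyl in the step of no change at the digits printed from compound 3 to compound 4 (within the scatter) in this assay, and the same group replaces ethyl in the step of a number 0.8 percentage points lower from compound 2 to compound 4 (within the scatter), so all three groups at this place read alike at this single concentration. The carbamate also reads the same with either side chain, since 3-methylbut-2-en-1-yl in place of hydrogen on a saturated chain carbon bound to a double-bonded chain carbon gives no change at the digits printed from compound 1 to compound 4 (within the scatter). Nothing available here accounts for these numbers.

Still open, going by these compounds, is whether any group at this oxygen can lift the reading beyond the scatter. A chain ending in an amine or a carboxylic acid would be one such test.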